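Removing the bromoacrylamide of compound 2: an expectation

The source may report more compounds than this note shows. Statements on the series, on what has been measured and on what is new or still open speak of the compounds shown alone.

Measured compounds:
Compound 1, `C=C(Br)C(=O)Nc1cccc(-c2cn3nc(-c4ccc(F)cc4)sc3n2)c1`, 610 nM
Compound 2, `C=C(Br)C(=O)Nc1cccc(-c2cn3nc(-c4ccccc4)sc3n2)c1`, 900 nM
Compound 3, `C=C(Br)C(=O)Nc1cccc(-c2cn3nc(-c4ccc(OCC)cc4)sc3n2)c1`, 1100 nM

In a functional assay on FM3A cells (Mus musculus) for inhibition, read by cell counting, with a stated time of 2 days (a lower number here means a stronger inhibitor, a higher number a weaker inhibitor), compound 2 gives 900 nM, the second highest of the three numbers; compound 1 sits close, at a 1.5-fold higher number from compound 1 to compound 2 (0.17 log units; within the scatter), and compound 3 still closer, at a 1.2-fold higher number from compound 2 to compound 3 (0.09 log units; within the scatter), so the three cannot be ordered. The remaining step, a 1.8-fold higher number from compound 1 to compound 3 (0.26 log units; within the scatter), is likewise within the scatter. All three steps concern the aromatic ring at the far end of the shared core.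

Compound 4, `Nc1cccc(-c2cn3nc(-c4ccccc4)sc3n2)c1`, differs from compound 2 at the other end: hydrogen in place of (1-bromoethenyl)carbonyl on a nitrogen on an aromatic ring. Among the measured compounds shown here, none of the measured steps touches this nitrogen or this group, so the measured series gives no direct guide to its effect. The group that leaves is large relative to the hydrogen that enters, and no measured change at this position exists for comparison. The estimate for compound 4 is set to the weaker side with a wide range: compound 4 is expected to give 4000 nM, between 800 nM and 20000 nM. This means an expected step of a 4.4-fold higher number from compound 2 to compound 4 (0.65 log units; beyond the scatter).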

Compound 4, half-maximal inhibitory concentration: 14000 nM
Estimate against measurement, compound 4: 3.5-fold (0.54 log units) below; low and high end bracket the measured number.
By their numbers in this assay, from the lowest: compounds 1, 2 and 3 (each within the scatter of the next); then compound 4.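

In this assay, the change from ((1-bromoethenyl)carbonyl)amino to amino gives a 16-fold higher number from compound 2 to compound 4 (1.19 log units; beyond the scatter) and is the only step among these compounds that lies beyond the scatter. The nitrogen end of the molecule therefore affects this read-out in a way that the changes on the far aromatic ring of compounds 1, 2 and 3 did not show, although compound 4 still gives a measured number. The compounds carry no information on why the loss of this group has so large an effect.

Which part of the group accounts for the step remains open: an acetyl or a plain acryloyl group on this nitrogen would separate the contributions of the bromine, the double bond and the carbonyl. Also open, from the compounds shown here alone, is whether fluoro or ethoxy on the far ring would behave the same way with the free amino group.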